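Swapping the chain amine: piperidine to methylpiperazine

The source may report more compounds than this note shows. Statements on the series, on what has been measured and on what is new or still open speak of the compounds shown alone.

Measured so far in a functional assay on NCI-H460 cells (Homo sapiens) for inhibition, read by MTT assay, with a stated time of 72 h; on this read-out lower numbers stand for stronger inhibition and higher numbers for weaker inhibition:
compound 1 `COc1cc2c(Oc3ccc(NC(=O)c4nn(-c5ccccc5)c(=O)cc4C)cc3F)ccnc2cc1OCCCN1CCN(C)CC1`: 360 nM
compound 2 `COc1cc2c(Oc3ccc(NC(=O)c4nn(-c5cccc(F)c5)c(=O)cc4C)cc3F)ccnc2cc1OCCCN1CCN(C)CC1`: 260 nM
compound 3 `COc1cc2c(Oc3ccc(NC(=O)c4nn(-c5ccc(Cl)cc5)c(=O)cc4C)cc3F)ccnc2cc1OCCCN1CCCCC1`: 460 nM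

Among these three numbers compound 3 gives the highest one, yet its gaps to compound 1 and to compound 2 both lie within the usual scatter of repeated measurements, so no order among the three can be read from them.

Compound 4 `COc1cc2c(Oc3ccc(NC(=O)c4nn(-c5ccc(Cl)cc5)c(=O)cc4C)cc3F)ccnc2cc1OCCCN1CCN(C)CC1` has not yet been measured. It differs from compound 3 in one place: 4-methylpiperazin-1-yl in place of piperidin-1-yl on a saturated chain carbon, three bonds along the chain from an oxygen on an aromatic ring. The rest of the molecule, including the chloro-bearing ring, is kept.

Among the measured compounds shown here, no measured pair shows this exact change. For the measured compounds named here, the only single-point step available, a 1.4-fold lower number from compound 1 to compound 2 (0.14 log units; within the scatter), concerns a different change on an aromatic carbon and stays within the scatter. Going by the values given here, compound 1 already carries the 4-methylpiperazin-1-yl group together with an unsubstituted aromatic ring, and its number sits close to that of compound 3; the two differ in two places, so no step between them is counted here.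

With nothing showing that either amine shifts the number, the expected step of a 1.3-fold lower number from compound 3 to compound 4 (0.11 log units; within the scatter) for compound 4 is small, in no clear direction and within the scatter. The estimate for compound 4 in this assay is 360 nM, with a likely range from 160 nM to 800 nM.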

Compound 4, half-maximal inhibitory concentration: 440 nM
Estimate against measurement, compound 4: 1.2-fold (0.09 log units) below; the range from low to high includes it.
By their numbers in this assay, from the lowest: compounds 2, 1, 4 and 3 (each within the scatter of the next).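

Read directly for the first time in this assay, the change from piperidin-1-yl to 4-methylpiperazin-1-yl, on a saturated chain carbon three bonds along the chain from an oxygen on an aromatic ring, gives a 1.0-fold lower number from compound 3 to compound 4 (0.02 log units; within the scatter) in the one pair available, so this exchange of amines produces no readable shift in the number. Compound 4 also links the chloro-bearing ring to the other two 4-methylpiperazin-1-yl compounds: adding a chloro group to the unsubstituted aromatic ring gives a 1.2-fold higher number from compound 1 to compound 4 (0.09 log units; within the scatter) and 4-chlorophenyl in place of 3-fluorophenyl on an aromatic nitrogen gives a 1.7-fold higher number from compound 2 to compound 4 (0.23 log units; within the scatter) and neither change separates the compounds beyond the scatter. No supporting measurement is available to explain these results.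

The compounds shown leave open what a morpholine, a dimethylamino group or a carboxylic acid at the end of the chain would do, and whether a longer chain, such as a butyl linker, would shift the number. They also leave open whether the piperidin-1-yl to 4-methylpiperazin-1-yl exchange would read the same with the unsubstituted phenyl or the 3-fluorophenyl ring in place.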